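Amide substituent swap in a growth-inhibition series

The source may report more compounds than this note shows. Statements on the series, on what has been measured and on what is new or still open speak of the compounds shown alone.

Measured compounds:
- compound 1 `O=C(Nc1sc2c(c1C(=O)NNc1ccccc1)CCCCC2)NS(=O)(=O)c1ccccc1`: in a functional assay on EKVX cells (Homo sapiens) for inhibition, with a stated time of 48 h (on this read-out higher numbers stand for weaker inhibition of growth and lower numbers for stronger inhibition of growth), compound 1 gives > 100000 nM, which is a limit of the assay and not a number.
- compound 2 `CCCNC(=O)c1c(NC(=O)NS(=O)(=O)c2ccccc2)sc2c1CCCCC2`: in this assay compound 2 gives 6200 nM.

For the measured compounds named here, compound 2 is the only compound with a number in this assay; the single other value is a limit. Going by the values given here, the one measured step, an at least 16-fold lower number from compound 1 to compound 2 (1.20 log units; beyond the scatter), is large, and it rests on a value that sits at the limit of > 100000 nM in this assay, at which 1 of the 2 values shown sits, so its true size is not known.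

Compound 3 `O=C(Nc1sc2c(c1C(=O)N1CCN(c3ccccc3)CC1)CCCCC2)NS(=O)(=O)c1ccccc1` is the next step from compound 2: 4-phenylpiperazin-1-yl in place of propylamino on a carbonyl carbon. The measured step from compound 1 to compound 2 concerns a different exchange on the amide nitrogen and bears only loosely on this one; it shows that the group on that carbonyl can move the number by a large amount. With an aromatic-bearing group entering again, compound 3 is expected to give a weaker number than compound 2, a step of a 3.2-fold higher number from compound 2 to compound 3 (0.51 log units; beyond the scatter). The estimate for compound 3 in this assay is 20000 nM, between 4000 nM and 100000 nM.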

Compound 3, concentration for 50% growth inhibition: > 100000 nM
Compound 3 gave a limit, no number; the forecaster's own chance of this, stated with the estimate: 30%; at least 5.0-fold (0.69 log units) between middle value and limit.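

In this assay, 4-phenylpiperazin-1-yl in place of propylamino on the carbonyl carbon gives an at least 16-fold higher number from compound 2 to compound 3 (1.20 log units; beyond the scatter), so a second group on this carbonyl, of a different build from the anilinoamino of compound 1, also moves the read-out by a large amount. Compound 3 gives > 100000 nM, which is a limit of the assay and not a number. Among these three compounds, the two groups carrying a phenyl ring, anilinoamino in compound 1 and 4-phenylpiperazin-1-yl in compound 3, both end at the limit, even though only the second holds a non-aromatic ring, and compound 2 with its propylamino remains the only one with a number.

On these data alone, the step between compound 1 and compound 3 cannot be read, and how far either compound lies past the limit stays open: the limit of > 100000 nM in this assay, at which 2 of the 3 values shown sit. A piperazine without the phenyl ring would separate the part played by the phenyl ring from that of the ring holding it, and a butyl chain on the amide nitrogen would show whether the number of compound 2 can move any lower.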